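Replacing a fluorine on compound 3's sulfonamide aryl group

The compounds below may be only part of what the source reports. "The series", "measured", "known", "first", "only" and "open" are said of these compounds alone.

Measured in a functional assay on K562 cells (Homo sapiens) for cytotoxicity, read by trypan blue exclusion, with a stated time of 96 h; on this read-out lower numbers stand for stronger inhibition and higher numbers for weaker inhibition:
- compound 1 `COc1cc(OC)c(/C=C/S(=O)(=O)Nc2ccc(F)c(N)c2)c(OC)c1`: 5000 nM
- compound 2 `O=S(=O)(/C=C/c1ccc(Br)cc1)Nc1ccc(F)cc1`: 10000 nM
- compound 3 `COc1cc(OC)c(/C=C/S(=O)(=O)Nc2ccc(OC)c(F)c2)c(OC)c1`: 75 nM

Of these three, compound 3 has the lowest number, at 75 nM. Compound 4 `COc1cc(OC)c(/C=C/S(=O)(=O)Nc2ccc(OC)c(OP(=O)(O)O)c2)c(OC)c1` differs from it by a group of 5 heavy atoms (4 oxygen, 1 phosphorus; no ring) in place of one fluorine atom, on an aromatic carbon, on an aromatic carbon, ortho to a methoxy group. Within the data shown here, one measured step bears on this change: a 67-fold lower number from compound 1 to compound 3 (1.82 log units; beyond the scatter). It shows that swapping the aryl group on the sulfonamide nitrogen can move the number a long way, though it does not test this replacement. A large step to a higher number in this assay is therefore expected, with wide uncertainty. The estimated step is a 2.7-fold higher number from compound 3 to compound 4 (0.43 log units; beyond the scatter). The expected value for compound 4 is 200 nM, with an estimated range from 20 nM to 2500 nM.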

Compound 4, half-maximal inhibitory concentration: 7.5 nM
Estimate against measurement, compound 4: 27-fold (1.43 log units) above; the whole stated range lies above it.
By their numbers in this assay, from the lowest: compound 4; then compound 3; then compounds 1 and 2 (each within the scatter of the next).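

In this assay, the group of 5 heavy atoms in place of fluoro gives a 10-fold lower number from compound 3 to compound 4 (1.00 log units; beyond the scatter). This place on the aromatic ring, ortho to a methoxy group, therefore accepts a far larger group than fluoro without losing activity, which the earlier step, a swap of the whole aryl group, could not show. Nothing available explains this gain. The compounds shown leave open whether the phosphorus-bearing group itself is needed, or whether a hydroxyl group or a carboxylic acid at this place would also give a lower number.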